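A Halogen Swap at One Aromatic Carbon

A few compounds are considered here, and "the series" means these few. Any claim that something is new, unique, unknown or untested is made for them only; others in the source may bear on it.

Measured compounds:
compound 1, `O=C(Nc1ccc(-n2ncc3c(C(F)(F)F)cccc32)cc1)Nc1ccc(Cl)c(C(F)(F)F)c1` — 2000 nM
compound 2, `O=C(Nc1ccc(-n2ncc3c(Cl)cccc32)cc1)Nc1ccc(Cl)c(C(F)(F)F)c1` — 1600 nM

In a functional assay on MDA-MB-231 cells (Homo sapiens) for cytotoxicity, read by MTT assay, with a stated time of 72 h (on this read-out higher numbers stand for weaker inhibition and lower numbers for stronger inhibition), compound 1 gives 2000 nM. In the same assay compound 2 gives 1600 nM, the lowest of the two numbers shown, yet its only neighbour is compound 1, and the step of a 1.3-fold lower number from compound 1 to compound 2 (0.10 log units; within the scatter) lies within the scatter, so the two cannot be ordered. Compound 3, `O=C(Nc1ccc(-n2ncc3c(Br)cccc32)cc1)Nc1ccc(Cl)c(C(F)(F)F)c1`, has not been measured. It differs from compound 2 by bromo in place of chloro on an aromatic carbon. For the measured compounds named here, the one measured step that bears on this change, a 1.3-fold lower number from compound 1 to compound 2 (0.10 log units; within the scatter), also swaps one small group for another at this very carbon and produced no shift beyond the scatter. On that basis the step from compound 2 to compound 3 in this assay is expected to be a 1.1-fold lower number from compound 2 to compound 3 (0.03 log units; within the scatter), no change beyond the scatter. Compound 3 is therefore estimated at 1500 nM, within a range from 700 nM to 3200 nM.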

Compound 3, half-maximal inhibitory concentration: 7700 nM
Beside the measured number, compound 3's estimate is 5.1-fold (0.71 log units) below it; measured number outside the range, above it.
By their numbers in this assay, from the lowest: compounds 2 and 1 (each within the scatter of the next); then compound 3.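

In this assay this aromatic carbon proves sensitive to the choice of group after all: exchanging chloro for bromo gives a 4.8-fold higher number from compound 2 to compound 3 (0.68 log units; beyond the scatter) and exchanging trifluoromethyl for bromo gives a 3.9-fold higher number from compound 1 to compound 3 (0.59 log units; beyond the scatter) in the same direction. Among these three compounds bromo therefore stands apart, while chloro and trifluoromethyl remain unordered, since the step between them, a 1.3-fold lower number from compound 1 to compound 2 (0.10 log units; within the scatter), does not leave the scatter. Nothing at hand explains why bromo departs from the other two groups.

Going by these compounds, it remains open whether fluoro, a methyl group, a methoxy group or an amine at this carbon would fall with chloro and trifluoromethyl or with bromo. Also open, on these data alone, is whether the step to bromo would recur with the rest of the molecule changed.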